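The source may report more compounds than this note shows. Statements on the series, on what has been measured and on what is new or still open speak of the compounds shown alone.

Measured compounds, in a functional assay on UACC-62 cells (Homo sapiens) for inhibition, read by sulforhodamine B assay, with a stated time of 48 h, tested at 10 uM; on this read-out higher numbers stand for a weaker effect at the one concentration tested and lower numbers for a stronger effect:
- compound 1 `COc1cc2cc(Oc3ccc(NC(=O)Nc4ccccc4)cc3)c(C)nc2cc1OC`: 88.4%
- compound 2 `COc1cc2cc(Oc3ccc(NC(=O)Nc4ccc(C)cc4)cc3)c(C)nc2cc1OC`: 99.3%
- compound 3 `COc1cc2cc(Oc3ccc(NC(=O)Nc4ccc(Cl)c(C(F)(F)F)c4)cc3)c(C)nc2cc1OC`: -51.5%

Compound 3 stands lowest of the three numbers in this assay, and by a wide margin: compound 1 is the nearest, a number 139.9 percentage points lower from compound 1 to compound 3 (beyond the scatter), and compound 2 the furthest, a number 150.8 percentage points lower from compound 2 to compound 3 (beyond the scatter). Between compound 1 and compound 2 the gap is small by comparison, a number 10.9 percentage points higher from compound 1 to compound 2 (beyond the scatter). The whole spread of the series therefore lies in the aryl group on the amide-type nitrogen of the urea.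

Compound 4 `COc1cc2cc(Oc3ccc(NC(=O)Nc4ccc(Cl)c(Cl)c4)cc3)c(C)nc2cc1OC` keeps the core and the urea of compound 3 and differs in one place: chloro in place of trifluoromethyl on an aromatic carbon. Going by the values given here, no measured step in this assay changes only this group, so there is no direct precedent for the size of the step. The two large steps, from compound 1 to compound 3 and from compound 2 to compound 3, show that a halogenated aryl on this nitrogen sets the low end; compound 4 retains the chloro group of compound 3 and adds a second chloro, so it is expected to stay in the strong region rather than return toward compound 1 or compound 2. Some loss is allowed for, since the change is untested here. The expected step is a number 31.5 percentage points higher from compound 3 to compound 4 (beyond the scatter). For compound 4 in this assay the estimate is -20%, with a range from -65% to 35%.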

Compound 4, a percentage reported as activity, at one concentration (the size of the read-out at that concentration, not a potency): 20.4%
Estimate against measurement, compound 4: 40.4 percentage points below; the range from low to high includes it.
By their numbers in this assay, from the lowest: compound 3; then compound 4; then compound 1; then compound 2.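

In this assay, the trifluoromethyl group on this aromatic carbon, ortho to a chloro group, cannot be exchanged for chloro without a large loss: the step is a number 71.9 percentage points higher from compound 3 to compound 4 (beyond the scatter), so the low end of the series depends on this one group and not merely on the aryl group carrying halogen. The 3,4-dichlorophenyl group still retains much of the gain over the two aryl groups without halogen, with a number 68 percentage points lower from compound 1 to compound 4 (beyond the scatter) and a number 78.9 percentage points lower from compound 2 to compound 4 (beyond the scatter), which places compound 4 at an intermediate level among these four compounds rather than with either extreme. Nothing measured for these compounds accounts for the size of the exchange.

Open, from the compounds shown here alone, is where a nitrile or a bromo group on the same aromatic carbon would stand relative to compound 3 and compound 4. Also open, going by these compounds, is whether trifluoromethyl on this carbon would give a step of similar size with hydrogen in place of the chloro group ortho to it, and how these differences at a single concentration would carry over to full concentration-response measurements.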